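From 2-cyanoethyl to 2-cyanoethenyl in compound 4

The source may report more compounds than this note shows. Statements on the series, on what has been measured and on what is new or still open speak of the compounds shown alone.

Compounds measured so far in an ADME assay on TZM cells (Homo sapiens) for cytotoxicity, read by XTT assay, with a stated time of 4 days; a lower number here means that less compound is tolerated, a higher number that more compound is tolerated

- Compound 1 `CC(=O)CCc1cc(C)c(Oc2cc(Nc3ccc(C#N)cc3)c(N)cc2C(F)(F)F)c(C)c1` gives 11100 nM as a number
- Compound 2 `Cc1cc(/C=C/C#N)cc(C)c1Oc1cc(Nc2ccc(C#N)cc2)c(N)cc1S(N)(=O)=O` gives > 21800 nM as a limit
- Compound 3 `Cc1cc(CCC#N)cc(C)c1Oc1cc(Nc2ccc(C#N)cc2)c(N)cc1C(F)(F)F` gives > 7100 nM as a limit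

Compound 3 stands on a limit and not on a number (> 7100 nM). Its place among the three compounds therefore cannot be fixed.

The next compound is compound 4 `Cc1cc(/C=C/C#N)cc(C)c1Oc1cc(Nc2ccc(C#N)cc2)c(N)cc1C(F)(F)F`, which differs from compound 3 in one place (2-cyanoethenyl in place of 2-cyanoethyl on an aromatic carbon). In words, 2-cyanoethenyl stands in place of 2-cyanoethyl on an aromatic carbon, meta to two methyl groups and para to a large group.

Within the data shown here, only one measured step bears on this change, and it gives no size: a step that the limit leaves unreadable from compound 1 to compound 3. Among the measured compounds shown here, compound 1 still offers the one plain number (11100 nM). Compound 2 carries the same 2-cyanoethenyl group and is also reported only as a limit (> 21800 nM).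

With so little to read, no step beyond the scatter is foreseen in this assay, and no direction can be argued. The expected outcome is a step that the limit leaves unreadable from compound 3 to compound 4, an estimate that rests on these few values. For compound 4 the estimated value is 10000 nM, with an expected range from 4000 nM to 25000 nM, and it may be reported only as a limit.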

Compound 4, half-maximal cytotoxic concentration: 15000 nM
For compound 4 the middle estimate is 1.5-fold (0.18 log units) below the measured one; the range from low to high includes it.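

Compound 4 gives the 2-cyanoethenyl group its first plain number in this assay, and set against the 2-acetylethyl group of compound 1 this change gives a 1.4-fold higher number from compound 1 to compound 4 (0.13 log units; within the scatter), so the two groups are not told apart on this aromatic carbon. Trifluoromethyl in place of sulfamoyl gives an at least 1.4-fold lower number from compound 2 to compound 4 (0.16 log units; that floor lies within the scatter), which is only a floor and so does not settle how large that step is. The step from the 2-cyanoethyl group to the 2-cyanoethenyl group cannot be read, because compound 3 is reported only as a limit: the limit of > 7100 nM in this assay, at which 1 of the 4 values shown sits.

From the compounds shown here alone, it therefore remains open whether the double bond in the chain makes any difference at all in this assay, and a plain number for compound 3 would be needed to tell. Also open, going by these compounds, is how an amine, a carboxylic acid or a longer chain on this aromatic carbon would read in this assay, and whether any such group would move the number beyond the scatter.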